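The source may report more compounds than this note shows. Statements on the series, on what has been measured and on what is new or still open speak of the compounds shown alone.

Compound 3 (`COc1ccc(S(=O)(=O)N2CCc3cccc(NCc4ccccc4)c32)cc1`) reads > 10000 nM in a functional assay on KB cells (Homo sapiens) for cytotoxicity (a higher number here means a weaker inhibitor, a lower number a stronger inhibitor), a limit and not a number. Compound 2 (`COc1ccc(S(=O)(=O)N2CCc3cccc(NC(=O)Oc4ccccc4)c32)cc1`) reads > 10000 nM, also a limit. Among the compounds with values here, compound 1 (`COc1ccc(S(=O)(=O)N2CCc3cccc(NS(=O)(=O)c4ccc(F)cc4)c32)cc1`) gives 1200 nM, the only true number so far. Compound 3 therefore stands at the limit of > 10000 nM in this assay, at which 2 of the 3 values shown sit.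

Compound 4 (`COc1ccc(S(=O)(=O)N2CCc3cccc(NC(=O)c4ccccc4)c32)cc1`) puts benzoyl in place of benzyl on a nitrogen on an aromatic ring. The nearest evidence is an at least 8.3-fold higher number from compound 1 to compound 2 (0.92 log units; beyond the scatter) and an at least 8.3-fold higher number from compound 1 to compound 3 (0.92 log units; beyond the scatter), both beyond the scatter, while a step that the two limits leave unreadable from compound 2 to compound 3 cannot be sized. Neither phenoxycarbonyl nor benzyl held a number, so no recovery towards compound 1 is expected in this assay. The expected step is a number no higher from compound 3 to compound 4 (the limit leaves the size open), probably no readable change. Compound 4 is estimated at 10000 nM, within 3000 nM to 30000 nM.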

Compound 4, half-maximal inhibitory concentration: 297 nM
Beside the measured number, compound 4's estimate is 34-fold (1.53 log units) above it; measured number outside the range, below it.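

In this assay the nitrogen on an aromatic ring proves sensitive to the attached group, with an at least 33-fold lower number from compound 3 to compound 4 (1.52 log units; beyond the scatter) for benzoyl in place of benzyl and an at least 33-fold lower number from compound 2 to compound 4 (1.52 log units; beyond the scatter) for phenyl in place of phenoxy on a carbonyl carbon. A carbonyl on this nitrogen is not sufficient on its own, as compound 2 also carries one and reads only as a limit. Benzoyl also improves on (4-fluorophenyl)sulfonyl, with a 4.0-fold lower number from compound 1 to compound 4 (0.61 log units; beyond the scatter) for that change.

On these data alone, whether an amine or methoxy on the benzoyl ring, or an acetyl in place of benzoyl, would keep this potency stays open. The full size of the two steps from limits cannot be read.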